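A few compounds are considered here, and "the series" means these few. Any claim that something is new, unique, unknown or untested is made for them only; others in the source may bear on it.

Measured compounds in a functional assay on RXF 393 cells (Homo sapiens) for inhibition, read by sulforhodamine B assay, with a stated time of 48 h; on this read-out lower numbers stand for higher toxicity in this test and higher numbers for lower toxicity in this test:
compound 1 `Nc1cc(N)c2nc(-c3ccccc3)c(NCc3ccc(F)cc3)nc2c1` gives 60300 nM
compound 2 `COc1ccc(Sc2nc3cc(N)cc(N)c3nc2-c2ccccc2)cc1` gives only a limit, < 100000 nM

Compound 2 stands at the limit of this assay, so its value is not a number and cannot be placed against compound 1. The step from compound 1 to compound 2, a step that the limit leaves unreadable from compound 1 to compound 2, is therefore unreadable, as the limit of < 100000 nM in this assay, at which 1 of the 2 values shown sits, shows.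

Compound 3 `Nc1cc(N)c2nc(-c3ccccc3)c(Oc3ccc(F)cc3)nc2c1` differs from compound 2 as follows: 4-fluorophenoxy in place of (4-methoxyphenyl)sulfanyl on an aromatic carbon. No measured step bears directly on this exchange, since the only step shown is the unreadable one from compound 1 to compound 2. The expectation for compound 3 rests on compound 1, whose measured value 60300 nM is the sole numeric anchor in this assay, and on the weak activity of the series as a whole.

The estimated step that the limit leaves unreadable from compound 2 to compound 3 from compound 2 to compound 3 is not resolvable beyond the scatter. Compound 3 is estimated at 55000 nM, with a range from 15000 nM to 150000 nM, and a fair chance that this assay again reports only a limit.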

Compound 3, concentration lethal to 50% of the cells: < 100000 nM
Compound 3: only a limit was reported; the forecaster's own chance of this, stated with the estimate: 35%; the middle value is on the limit's open side.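

Compound 3 gives < 100000 nM, a limit and not a number, so its steps from compound 1 and compound 2 cannot be read: the limit of < 100000 nM in this assay, at which 2 of the 3 values shown sit.

Still open, on these data alone, is how (4-methoxyphenyl)sulfanyl and 4-fluorophenoxy compare with (4-fluorobenzyl)amino on this aromatic carbon.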